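This account rests on a few compounds, and the source may have more. Where it says the series, first, only, none or still open, it means among the compounds named here.

In a functional assay on CCRF-CEM cells (Homo sapiens) for inhibition, read by MTT assay, with a stated time of 4 days (a higher number here means a weaker inhibitor, a lower number a stronger inhibitor), compound 1 `COc1cc(NC(C)CCCNC(=O)NCCNC(c2ccccc2)(c2ccccc2)c2ccccc2)c2ncccc2c1` gives 10000 nM, and compound 2 `COc1ccc(/C(=N/NC(=O)NCCCC(C)Nc2cc(OC)cc3cccnc23)c2ccccc2)cc1` gives 10000 nM. Compound 3 `COc1cc(NC(C)CCCNC(=O)NNC(=O)Nc2ccc(Cl)c(C(F)(F)F)c2)c2ncccc2c1` gives 14000 nM in this assay. Compound 3 sits alongside the other two: its number differs from that of compound 1 and from that of compound 2 by less than the usual scatter of repeated measurements, so nothing separates the three on these figures. Compound 4 `COc1cc(NC(C)CCCNC(=O)NNC(=O)NCCCO)c2ncccc2c1` has not yet been measured. It differs from compound 3 by 3-hydroxypropyl in place of 4-chloro-3-(trifluoromethyl)phenyl on an amide-type nitrogen. Going by the values given here, no measured pair in this set shows what such a change does, and all three numbers gathered so far lie in the same weak range. He therefore expects compound 4 to stay close to compound 3 in this assay, with a step from compound 3 to compound 4 of a 1.1-fold higher number from compound 3 to compound 4 (0.03 log units; within the scatter), which is not beyond the scatter. His estimate for compound 4 in this assay is 15000 nM, with a range from 7000 nM to 40000 nM.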

Compound 4, half-maximal inhibitory concentration: > 250000 nM
Compound 4 was reported as a limit (the forecaster's own chance of this, stated with the estimate: 30%); middle value at least 16-fold (1.22 log units) away from the limit.
By their numbers in this assay, from the lowest: compounds 1, 2 and 3 (each within the scatter of the next). At a limit, above all of these: compound 4.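

Compound 4 is reported in this assay only as a limit: the limit of > 250000 nM in this assay, at which 1 of the 4 values shown sits.

Going by these compounds alone, putting 3-hydroxypropyl in place of 4-chloro-3-(trifluoromethyl)phenyl on the amide-type nitrogen gives an at least 17-fold higher number from compound 3 to compound 4 (1.25 log units; beyond the scatter), the first step in the set between compounds that differ in one place, and it shows that the group at this position can move the number well beyond the scatter. This single pair changes the aromatic ring, the chlorine, the trifluoromethyl and the hydroxyl all at once, and it does not separate their contributions.

On these data alone, it remains open whether a plain phenyl or an unbranched propyl chain on the same nitrogen would keep the number near that of compound 3, at 14000 nM. As far as these compounds go, it is equally open what an amine, a carboxylic acid or a longer chain bearing a hydroxyl would do there.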